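Fluoro Replaces Nitro on an Aryl Ether Oxazoline

The source may hold more compounds than are shown below. What is called first, only, known or untested is meant among the compounds shown, and "the series" means these compounds.

In a toxicity assay on the whole organism with Rattus norvegicus as the target, at a dose of 100 mg/kg by the oral route (a higher number here means a stronger effect of the compound at the dose given, a lower number a weaker effect), compound 1 `Clc1ccccc1OCC1=NCCO1` gives 40%, while compound 2 `O=[N+]([O-])c1ccccc1OCC1=NCCO1` gives 20%, the lowest of the two numbers measured, with the step of a number 20 percentage points lower from compound 1 to compound 2 (beyond the scatter) placing it beyond the scatter below compound 1. Compound 3 `Fc1ccccc1OCC1=NCCO1` is not yet measured in this assay and differs from compound 2 by fluoro in place of nitro on an aromatic carbon. Within the data shown here, only one measured step bears on this change: the step of a number 20 percentage points lower from compound 1 to compound 2 (beyond the scatter), in which nitro entered for chloro and the number fell modestly. Compound 3 now removes that nitro and puts a different halogen in its place, so the step partly undoes the change that produced compound 2, and a modest rise is expected in this assay, roughly a number 15 percentage points higher from compound 2 to compound 3 (beyond the scatter). Compound 3 is therefore estimated at 35% in this assay, with a range from 15% to 55%.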

Compound 3, a percentage reported as activity, at one dose (the size of the read-out at that dose, not a potency): 10%
Beside the measured number, compound 3's estimate is 25 percentage points above it; measured number outside the range, below it.
By their numbers in this assay, from the lowest: compounds 3 and 2 (each within the scatter of the next); then compound 1.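

In this assay, fluoro in place of nitro gives a number 10 percentage points lower from compound 2 to compound 3 (within the scatter), so on this aromatic carbon the two groups cannot be told apart, even though nitro brings three heavy atoms and fluoro only one. Fluoro in place of chloro gives a number 30 percentage points lower from compound 1 to compound 3 (beyond the scatter), which shows that the earlier drop from compound 1 was not tied to nitro alone, since compound 1 now stands apart from both of the others. Nothing available here speaks to what lies behind these numbers.

The compounds shown leave open whether the higher number belongs to chloro alone or would also appear with bromo or methyl on this aromatic carbon. They also leave open what an amine or a methoxy group would give there, and whether the same picture would hold at other doses.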